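The compounds below may be only part of what the source reports. "The series", "measured", "known", "first", "only" and "open" are said of these compounds alone.

Measured so far:
compound 1, `CC(C)=CCC[C@H](C)c1ccc(C)cc1O`: > 20000 nM
compound 2, `CC(C)=CCC[C@H](C)c1ccc(C)c(CNCCO)c1O`: > 20000 nM

In a functional assay on MCF7 cells (Homo sapiens) for inhibition, read by MTT assay, with a stated time of 72 h (a higher number here means a weaker inhibitor, a lower number a stronger inhibitor), compound 1 gives only a limit, > 20000 nM. Compound 2 likewise gives only a limit in this assay, > 20000 nM. The step that the two limits leave unreadable from compound 1 to compound 2 is therefore not readable, since both values sit at the limit of > 20000 nM in this assay, at which 2 of the 2 values shown sit. Compound 2 thus stands at the limit of this assay, with no measured number to place it.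

Compound 3, `CC(C)=CCC[C@H](C)c1ccc(C)c(CNCC2CCNCC2)c1O`, differs from compound 2 by piperidin-4-yl in place of hydroxymethyl on a saturated chain carbon bound to an amine nitrogen. Within the data shown here, no measured step touches this change, and the single measured step, a step that the two limits leave unreadable from compound 1 to compound 2, is itself unreadable from two limits. There is accordingly no basis to expect a step of any particular size or direction in this assay beyond the scatter. The working expectation is that compound 3 again reports only a limit in this assay. As a number, compound 3 is estimated at 25000 nM, with a range from 5000 nM to 100000 nM. This estimate amounts to an expected step that the limit leaves unreadable from compound 2 to compound 3.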

Compound 3, half-maximal inhibitory concentration: > 20000 nM
Compound 3 was reported as a limit (the forecaster's own chance of this, stated with the estimate: 80%); the middle value lies beyond the limit too.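

In this assay, compound 3 gives only a limit, > 20000 nM, so no step from compound 2 can be read: the limit of > 20000 nM in this assay, at which 3 of the 3 values shown sit.

The compounds shown leave open whether any change to the shared core gives a measured number in this assay.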